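A few compounds are considered here, and "the series" means these few. Any claim that something is new, unique, unknown or untested is made for them only; others in the source may bear on it.

Measured in a functional assay on MCF7 cells (Homo sapiens) for cytotoxicity, read by MTT assay, with a stated time of 96 h; on this read-out lower numbers stand for stronger inhibition and higher numbers for weaker inhibition:
compound 1 `COc1cc(C(=O)c2cn(-c3ccccc3)cc2-c2ccc([N+](=O)[O-])cc2)cc(OC)c1OC` (590 nM)
compound 2 `COc1cc(C(=O)c2cn(-c3cccc(C)c3)cc2-c2ccccc2F)cc(OC)c1OC` (190 nM)
compound 3 `COc1cc(C(=O)c2cn(-c3cccc(C)c3)cc2-c2ccccc2Cl)cc(OC)c1OC` (420 nM)

Compound 3 (420 nM) lies within the scatter of compound 1 (590 nM). The comparison with compound 2 shows a 2.2-fold higher number from compound 2 to compound 3 (0.34 log units; beyond the scatter) at the same place on the shared core. That modest step is the only one measured there, and it does not involve 4-nitrophenyl.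

Compound 4 `COc1cc(C(=O)c2cn(-c3cccc(C)c3)cc2-c2ccc([N+](=O)[O-])cc2)cc(OC)c1OC` carries 4-nitrophenyl in place of 2-chlorophenyl on an aromatic carbon and keeps the 3-methylphenyl group. Within the data shown here, compound 1 (590 nM) carries the same 4-nitrophenyl but lacks that 3-methylphenyl group, so no measured step isolates the exchange.

In this assay the expected step is a 1.1-fold higher number from compound 3 to compound 4 (0.03 log units; within the scatter) and thus none beyond the scatter. The estimate for compound 4 is 450 nM, with an expected range of 150 nM to 1300 nM.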

Compound 4, half-maximal inhibitory concentration: 780 nM
Compound 4: middle estimate off by 1.7-fold (0.24 log units), on the low side; low and high end bracket the measured number.
By their numbers in this assay, from the lowest: compound 2; then compounds 3, 1 and 4 (each within the scatter of the next).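

In this assay the exchange at this position gives a 1.9-fold higher number from compound 3 to compound 4 (0.27 log units; within the scatter) and, set against 2-fluorophenyl, a 4.1-fold higher number from compound 2 to compound 4 (0.61 log units; beyond the scatter), so among the compounds with the 3-methylphenyl group, compound 2 alone stands apart from the other two. With 4-nitrophenyl in place, methyl on the aromatic carbon gives a 1.3-fold higher number from compound 1 to compound 4 (0.12 log units; within the scatter), a step that shows no effect of this methyl beyond the scatter. Nothing at hand accounts for these steps.

On these data alone, how an aminophenyl or carboxyphenyl group would read at this position remains open. Also open, as far as these compounds go, is whether 2-fluorophenyl keeps its standing without that methyl.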